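Phenoxy on the seven-membered ring of compound 1

The compounds below may be only part of what the source reports. "The series", "measured", "known", "first", "only" and "open" are said of these compounds alone.

Measured compounds:
- compound 1, `CCOC(=O)C(=O)Nc1cccccc1=O`: 84%
- compound 2, `CCOC(=O)C(=O)Nc1ccc(O)c(=O)cc1`: 10%
- compound 3, `COC(=O)C(=O)Nc1ccc(OC)c(=O)cc1`: 36%

In a functional assay on the whole organism (strain Sprague-Dawley CD) for inhibition, with Rattus norvegicus as the target, read by paw edema, at a dose of 30 mg/kg by the intraperitoneal route (on this read-out lower numbers stand for a weaker effect and higher numbers for a stronger effect at the one dose given), compound 1 gives 84%, the highest of the three numbers. Compound 3 gives 36% in this assay, a gap beyond the scatter, and compound 2 gives 10%, further still. Among the compounds with values here, compound 1 thus shows the strongest effect of the measured set, with both of its gaps beyond the scatter; no single-place step between the measured compounds is available, so nothing connects these three through a shared change.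

Compound 4, `CCOC(=O)C(=O)Nc1c(Oc2ccccc2)ccccc1=O`, is not yet measured. It differs from compound 1 in one place: phenoxy in place of hydrogen on an aromatic carbon. Within the data shown here, no measured pair tells what a phenoxy group brings on this core, so the expectation rests on compound 1 alone.

Compound 4 is expected to stay in the upper part of the range but probably not to match compound 1, the step of a number 19 percentage points lower from compound 1 to compound 4 (beyond the scatter) being estimated as a modest loss that may well fall inside the scatter. The estimate for compound 4 in this assay is 65%, with a range from 35% to 90%.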

Compound 4, a percentage reported as inhibition, in the whole organism at one dose (the size of the read-out at that dose, not a potency): 0%
The estimate for compound 4 lay 65 percentage points above the measured number; measured number outside the range, below it.
By their numbers in this assay, from the lowest: compounds 4 and 2 (each within the scatter of the next); then compound 3; then compound 1.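

In this assay, phenoxy in place of hydrogen on an aromatic carbon of the seven-membered ring, next to the ring atom that bears a group of 8 heavy atoms, gives a number 84 percentage points lower from compound 1 to compound 4 (beyond the scatter). The earlier compounds shown here offered no single-place step, whereas this pair ties a large loss to one change at one position on the core of compound 1. Nothing available bears on the reason for this loss.

As far as these compounds go, whether the loss belongs to phenoxy specifically or extends to other groups at this carbon remains open. A methoxy group, a fluorine atom or an amine in the same place would show whether any substituent there is compatible with the effect at the one dose given, and phenoxy at other ring carbons also remains unresolved.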